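This account rests on a few compounds, and the source may have more. Where it says the series, first, only, none or still open, it means among the compounds named here.

Measured so far in a functional assay on aorta (strain Wistar) for inhibition, with Thoracic aorta (Rattus norvegicus) as the target; on this read-out higher numbers stand for weaker inhibition and lower numbers for stronger inhibition: compound 1 `CCOc1nc(-c2cc3ccccc3o2)cc(-c2ccc3ccccc3c2)c1C#N` gives 423000 nM, compound 2 `CCOc1nc(-c2cc3ccccc3o2)cc(-c2ccc(Cl)cc2)c1C#N` gives 221000 nM, and compound 3 `CCOc1nc(-c2cc3ccccc3o2)cc(-c2cccs2)c1C#N` gives 308000 nM.

All three numbers sit close together: the steps of a 1.4-fold lower number from compound 1 to compound 3 (0.14 log units; within the scatter) and a 1.4-fold higher number from compound 2 to compound 3 (0.14 log units; within the scatter) both lie within the scatter, as does a 1.9-fold lower number from compound 1 to compound 2 (0.28 log units; within the scatter), so compound 3 cannot be set apart from either companion.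

Compound 4 `CCOc1nc(-c2cc3ccccc3o2)cc(-c2cn(C)c3ccccc23)c1C#N` arises from compound 3 by 1-methyl-1H-indol-3-yl in place of thiophen-2-yl on an aromatic carbon. The three steps already seen swap the group at this same position among three different aromatic rings without moving the number beyond the scatter, so a further swap is expected to behave alike. For compound 4 the step of a 1.1-fold higher number from compound 3 to compound 4 (0.06 log units; within the scatter) is expected, within the scatter. Compound 4 is therefore estimated at 350000 nM in this assay, in the range 120000 nM to 1000000 nM.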

Compound 4, half-maximal inhibitory concentration: 327000 nM
Beside the measured number, compound 4's estimate is 1.1-fold (0.03 log units) above it; the measured number falls inside the stated range.
By their numbers in this assay, from the lowest: compounds 2, 3, 4 and 1 (each within the scatter of the next).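

In this assay, among the compounds shown here, 1-methyl-1H-indol-3-yl, opposite the ring nitrogen, is the first group with nitrogen seen at this position, and it also gives no clear change: a 1.1-fold higher number from compound 3 to compound 4 (0.03 log units; within the scatter) and a 1.5-fold higher number from compound 2 to compound 4 (0.17 log units; within the scatter) and a 1.3-fold lower number from compound 1 to compound 4 (0.11 log units; within the scatter) all lie within the scatter. Four different aromatic groups here, including two with fused rings, now cannot be told apart. No measurement shown offers an explanation for this flat result. Going by these compounds, whether a non-aromatic group here, such as an amine or a carboxylic acid, would move the number stays open.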